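Swapping the amide ring in a dioxygenase inhibitor series

This account rests on a few compounds, and the source may have more. Where it says the series, first, only, none or still open, it means among the compounds named here.

Measured compounds:
compound 1 `O=C(NCc1cccc(Cn2cnc3ccccc32)c1)c1cc(Br)c[nH]1`: 5460 nM
compound 2 `O=C(NCc1cccc(Cn2cnc3ccccc32)c1)c1cc2ccccc2[nH]1`: 13200 nM

Both compounds share one core and differ only in the ring joined to the carbonyl carbon of the amide. Within the data shown here, in an assay on P815 cells for inhibition of Tryptophan 2,3-dioxygenase (Mus musculus), read by HPLC, with a stated time of 16 h (on this read-out higher numbers stand for weaker inhibition and lower numbers for stronger inhibition), compound 2 gives 13200 nM, the highest of the two numbers; its only neighbour is compound 1, and the step of a 2.4-fold higher number from compound 1 to compound 2 (0.38 log units; beyond the scatter) is modest but beyond the scatter.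

Compound 3 `N#Cc1ccc(C(=O)NCc2cccc(Cn3cnc4ccccc43)c2)cc1` is not yet measured. It differs from compound 2 by 4-cyanophenyl in place of 1H-indol-2-yl on a carbonyl carbon. Among the measured compounds shown here, the one measured step that bears on this change is a 2.4-fold higher number from compound 1 to compound 2 (0.38 log units; beyond the scatter), since it also exchanged the ring on that carbonyl carbon and moved the number only modestly. Neither measured ring resembles 4-cyanophenyl closely, so the direction is uncertain. A modest step in this assay is expected, rather towards a lower number. Compound 3 is estimated at 8000 nM, with a range from 2500 nM to 30000 nM. This estimate means a step of a 1.7-fold lower number from compound 2 to compound 3 (0.22 log units; within the scatter).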

Compound 3, half-maximal inhibitory concentration: 32300 nM
Compound 3: the middle estimate sits 4.0-fold (0.61 log units) below what was measured; the measured number lies above the stated range.
By their numbers in this assay, from the lowest: compound 1; then compound 2; then compound 3.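

In this assay the change to 4-cyanophenyl on the carbonyl carbon gives a 2.4-fold higher number from compound 2 to compound 3 (0.39 log units; beyond the scatter) and, measured against the bromopyrrole ring, a 5.9-fold higher number from compound 1 to compound 3 (0.77 log units; beyond the scatter), which makes compound 3 the weakest inhibitor of the three. This position therefore tolerates ring changes without any gain so far, and the lowest number still belongs to compound 1. The change also removes the hydrogen-bond donor and the five-membered ring of 1H-indol-2-yl while adding a nitrile, and no measurement here explains the loss or separates these changes.

A plain phenyl ring on the same carbonyl carbon would show whether the nitrile matters on its own. An unsubstituted pyrrole ring would likewise show what the bromine contributes to compound 1.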